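The source may hold more compounds than are shown below. What is called first, only, known or untested is meant among the compounds shown, and "the series" means these compounds.

Within the data shown here, three compounds share one core and differ only in the single group carried on the aromatic ring. Compound 1 `O=C1NCCN(c2cccc(F)c2)N1` carries a fluoro group, and in an assay on RBL-1 cells for inhibition of Polyunsaturated fatty acid 5-lipoxygenase (Rattus norvegicus) (on this read-out lower numbers stand for stronger inhibition and higher numbers for weaker inhibition), compound 1 gives 19000 nM. Compound 2 `COc1cccc(N2CCNC(=O)N2)c1` carries a methoxy group, and in this assay compound 2 gives 47000 nM. Compound 3 `CSc1cccc(N2CCNC(=O)N2)c1` carries a methylsulfanyl group, and in this assay compound 3 gives 14000 nM. Among the measured compounds shown here, of the three numbers, the one for compound 3 is the lowest, but the step of a 1.4-fold lower number from compound 1 to compound 3 (0.13 log units; within the scatter) stays within the scatter, so compound 1 and compound 3 cannot be told apart on these data; the step of a 3.4-fold lower number from compound 2 to compound 3 (0.53 log units; beyond the scatter) lies beyond the scatter, as does the step of a 2.5-fold higher number from compound 1 to compound 2 (0.39 log units; beyond the scatter).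

Compound 4 `O=C1NCCN(c2cccc([N+](=O)[O-])c2)N1` takes the change (nitro in place of methylsulfanyl on an aromatic carbon). For the measured compounds named here, no measured step involves a nitro group, so none bears on this change directly. What the three measured steps show is how far the number moves when the group on this aromatic carbon is exchanged: modest at most, and in one case within the scatter. On that basis the step of a 1.4-fold higher number from compound 3 to compound 4 (0.15 log units; within the scatter) is expected to be modest at most, with no clear direction. For compound 4 in this assay the estimated value is 20000 nM, with a range from 7000 nM to 60000 nM.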

Compound 4, half-maximal inhibitory concentration: 49000 nM
For compound 4 the middle estimate is 2.5-fold (0.39 log units) below the measured one; the measured number falls inside the stated range.
By their numbers in this assay, from the lowest: compounds 3 and 1 (each within the scatter of the next); then compounds 2 and 4 (each within the scatter of the next).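

In this assay the nitro group lands with methoxy and apart from the other two groups: a 1.0-fold higher number from compound 2 to compound 4 (0.02 log units; within the scatter) stays within the scatter, so these two compounds cannot be told apart, while a 2.6-fold higher number from compound 1 to compound 4 (0.41 log units; beyond the scatter) and a 3.5-fold higher number from compound 3 to compound 4 (0.54 log units; beyond the scatter) both lie beyond it. The four groups on this aromatic carbon therefore fall into two pairs, with fluoro and methylsulfanyl giving the lower numbers and methoxy and nitro the higher ones, and within each pair the compounds cannot be told apart. Exchanging methylsulfanyl for nitro thus has a real but modest effect on the number, and nothing at hand explains why the groups divide in this way.

The compounds shown leave open whether any group on this carbon can move the number by more than a modest step, since an amine, a carboxylic acid or a longer chain such as ethoxy could behave differently from these four. They also leave open whether the same two pairs would appear if these groups sat on a different carbon of the aromatic ring.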